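A few compounds are considered here, and "the series" means these few. Any claim that something is new, unique, unknown or untested is made for them only; others in the source may bear on it.

In an assay on COS-7 cells for agonist activity at Free fatty acid receptor 1 (Homo sapiens), read by scintillation counting and inositol phosphate accumulation, with a stated time of 90 min (on this read-out lower numbers stand for an effect already at smaller amounts and higher numbers for an effect only at larger amounts of compound), compound 1 `Cc1cccc(Nc2nc(N)nc(COc3ccc4c(C)cc(=O)oc4c3)n2)c1` gives 1780 nM, and compound 2 `Cc1cc(=O)oc2cc(OCc3nc(N)nc(Nc4ccc5c(c4)COC5)n3)ccc12` gives 1330 nM; the change a 1.3-fold lower number from compound 1 to compound 2 (0.13 log units; within the scatter) leaves the two within the scatter of each other, so compound 2 stands beside compound 1 rather than apart from it. Compound 3 `Cc1ccc(Nc2nc(N)nc(COc3ccc4c(C)cc(=O)oc4c3)n2)cc1Cl` carries a group of 8 heavy atoms (7 carbon, 1 chlorine; one six-membered aromatic ring of carbon only) in place of a group of 9 heavy atoms (8 carbon, 1 oxygen; one five-membered non-aromatic ring with 1 hetero atom, one six-membered aromatic ring of carbon only), on a nitrogen on an aromatic ring. Going by the values given here, only the step from compound 1 to compound 2 bears on this place, and it stayed within the scatter, so no movement beyond the scatter is expected in this assay. Compound 3 is therefore estimated at 1500 nM, between 500 nM and 4500 nM, a step of a 1.1-fold higher number from compound 2 to compound 3 (0.05 log units; within the scatter).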

Compound 3, half-maximal effective concentration: 140 nM
The estimate for compound 3 lay 11-fold (1.03 log units) above the measured number, and the stated range ends above it.
By their numbers in this assay, from the lowest: compound 3; then compounds 2 and 1 (each within the scatter of the next).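

The aryl group on this nitrogen turns out to matter: the earlier change there stayed within the scatter, whereas 3-chloro-4-methylphenyl in place of 3-methylphenyl gives a 13-fold lower number from compound 1 to compound 3 (1.10 log units; beyond the scatter). The same group in place of the ring-bearing oxygen group of compound 2 gives a 9.5-fold lower number from compound 2 to compound 3 (0.98 log units; beyond the scatter), so both steps lie beyond the scatter. Nothing measured here explains this shift.

On these data alone, it remains open whether the chlorine can be exchanged for another halogen such as fluorine or bromine, or for trifluoromethyl. As far as these compounds go, how a carboxylic acid or an amine on this aryl ring would read is equally open.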